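This account rests on a few compounds, and the source may have more. Where it says the series, first, only, none or still open, it means among the compounds named here.

Within the data shown here, in an ADME assay on the whole organism (Rattus norvegicus, strain Fischer 344) for pharmacokinetics, at a dose of 3 mg/kg by the oral route (a higher number here means more compound in the circulation at the dose given, a lower number less compound in the circulation), two compounds with a shared core have numbers so far. Compound 1 `NC(=O)c1sc2nccc(N3CCC[C@H](COCCO)C3)c2c1N` reaches 326 nM, while compound 2 `CCOCCOC[C@H]1CCCN(c2ccnc3sc(C(N)=O)c(N)c23)C1` reaches 2120 nM, the higher of the two. Compound 3 `Cn1ccnc1COC[C@H]1CCCN(c2ccnc3sc(C(N)=O)c(N)c23)C1` keeps the shared core, but its chain is altered: 1-methyl-1H-imidazol-2-yl in place of ethoxymethyl on a saturated chain carbon bound to an oxygen on a saturated carbon. Here, 1-methyl-1H-imidazol-2-yl stands in place of ethoxymethyl on a saturated chain carbon bound to an oxygen on a saturated carbon. Among the measured compounds shown here, only one measured step offers guidance, and only loosely: a 6.5-fold higher number from compound 1 to compound 2 (0.81 log units; beyond the scatter), beyond the scatter, with ethyl in place of hydrogen on an oxygen on a saturated carbon. That step shows that a change in this chain can shift the number, but it involves a different group, so it cannot fix the direction here. With compound 2 already at 2120 nM, a modest fall seems somewhat more likely than a further rise, and the expected change is a 2.1-fold lower number from compound 2 to compound 3 (0.33 log units; beyond the scatter). Compound 3 is estimated at 1000 nM, with an expected range of 250 nM to 3000 nM.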

Compound 3, maximal plasma concentration: 37.7 nM
The estimate for compound 3 lay 27-fold (1.42 log units) above the measured number, and the stated range ends above it.
By their numbers in this assay, from the lowest: compound 3; then compound 1; then compound 2.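

In this assay, 1-methyl-1H-imidazol-2-yl in place of ethoxymethyl gives a 56-fold lower number from compound 2 to compound 3 (1.75 log units; beyond the scatter) and a large change, while the same group in place of hydroxymethyl gives an 8.6-fold lower number from compound 1 to compound 3 (0.94 log units; beyond the scatter) and a modest change. This chain can therefore move the number down as well as up, and the ring-bearing chain of compound 3 ends below both ring-free chains of compound 1 and compound 2. Nothing available explains this fall.

With a single ring-bearing chain, the compounds shown cannot tell whether the fall belongs to this particular imidazole or to a ring in this place more generally. A phenyl ring, an imidazole without its methyl group, or an amine in the same place could separate these possibilities, and a longer ether chain would show whether the number rises further beyond compound 2.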